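The source may hold more compounds than are shown below. What is called first, only, known or untested is meant among the compounds shown, and "the series" means these compounds.

Working notes on the series; the only read-out here is a functional assay on MT4 cells (Homo sapiens) for cytotoxicity (on this read-out higher numbers stand for weaker inhibition and lower numbers for stronger inhibition), and all values below come from it.

In this assay compound 1 (`N#Cc1c(N)cccc1[S+]([O-])c1cccc(C(F)(F)F)c1`) gives 125000 nM and compound 2 (`Cc1cc(O)cc(S(=O)(=O)c2cccc(N)c2C#N)c1`) gives 167000 nM with the two values lying within the scatter of each other. Among the measured compounds shown here, compound 2 therefore stands level with the only other numeric value in the set, and neither can be ranked over the other. Compound 3 (`N#Cc1c(N)cccc1S(=O)(=O)c1cccc2ccccc12`) returns only a limit (> 200000 nM) and not a number. For the measured compounds named here, no two measured compounds differ in one place, so the set holds no measured step to lean on.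

The next compound is compound 4 (`COc1cc(C)cc(S(=O)(=O)c2cccc(N)c2C#N)c1`), which carries methyl in place of hydrogen on an oxygen on an aromatic ring, that is, hydroxy to methoxy relative to compound 2. Compound 1 and compound 2 carry different groups on the shared core yet fall within the scatter of each other, so this single added methyl is expected to move the number little. The expected change (a 1.2-fold lower number from compound 2 to compound 4 (0.06 log units; within the scatter)) is none beyond the scatter, in either direction. For compound 4 the estimated value is 145000 nM with an expected range from 80000 nM to 200000 nM in this read-out.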

Compound 4, half-maximal inhibitory concentration: 94000 nM
Beside the measured number, compound 4's estimate is 1.5-fold (0.19 log units) above it; the measured number falls inside the stated range.
By their numbers in this assay, from the lowest: compounds 4, 1 and 2 (each within the scatter of the next). At a limit, above all of these: compound 3.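

In this assay the series now has its first measured step, and it falls at the oxygen on an aromatic ring, where hydroxy becomes methoxy: a 1.8-fold lower number from compound 2 to compound 4 (0.25 log units; within the scatter). Among the compounds shown here, at this position, then, methyl can take the place of hydrogen with no change that this read-out can tell from scatter, something the earlier compounds could not show, as none of them differed from another in one place only. Compound 3 remains a limit and not a number, so the read-out has a ceiling that the series must be read against: the limit of > 200000 nM in this assay, at which 1 of the 4 values shown sits.

On these data alone, a single step gives the size of one replacement only, so it remains open whether a longer chain on this oxygen, such as ethoxy, or an amine or a carboxylic acid in place of the hydroxy, would stay level with compound 2 or would move the number beyond the scatter. As far as these compounds go, it is also open whether hydroxy to methoxy would read the same way with a different group on the other side of the shared core, such as the trifluoromethyl of compound 1.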